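The compounds below may be only part of what the source reports. "The series", "measured", "known", "first", "only" and "open" are said of these compounds alone.

Working notes on the series. Among the measured compounds shown here, in a physicochemical assay for lipophilicity, in phosphate buffer, measured as octanol-water partition, with a stated time of 24 h (on this read-out higher numbers stand for higher lipophilicity and lower numbers for lower lipophilicity), compound 1 `Cc1ccc(Oc2ccc(/C=N/NC(=S)Nc3ccc(Cl)cc3)cc2)cc1` gives 5.97, the second highest of the three numbers so far; compound 2 `Cc1ccc(Oc2ccc(/C=N/NC(=S)Nc3ccc(Br)cc3)cc2)cc1` gives 6.17, and compound 3 `Cc1ccc(Oc2ccc(/C=N/NC(=S)Nc3ccc(F)cc3)cc2)cc1` gives 5.48. The steps between them, a number 0.20 log units higher from compound 1 to compound 2 (within the scatter), a number 0.49 log units lower from compound 1 to compound 3 (beyond the scatter) and a number 0.69 log units lower from compound 2 to compound 3 (beyond the scatter), all concern exchange of one halogen for another on an aromatic carbon. Compound 4 `S=C(N/N=C/c1ccc(Oc2ccc(Cl)cc2)cc1)Nc1ccc(Cl)cc1` differs from compound 1 by chloro in place of methyl on an aromatic carbon. For the measured compounds named here, no measured step matches this change; the halogen exchanges only show the scale that single-atom swaps reach in this assay. Compound 4 is therefore expected to sit close to compound 1, with an expected step of a number 0.13 log units higher from compound 1 to compound 4 (within the scatter) not beyond the scatter. The estimate for compound 4 is 6.1, within 5.7 to 6.5.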

Compound 4, partition coefficient: 6.2
The estimate for compound 4 lay 0.10 log units below the measured number; low and high end bracket the measured number.
By their numbers in this assay, from the lowest: compound 3; then compounds 1, 2 and 4 (each within the scatter of the next).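

Among the compounds shown here, this is the first step at the 4-methylphenoxy end of the series, since the earlier steps all exchanged one halogen for another elsewhere on the shared core. In this assay, chloro in place of methyl gives a number 0.23 log units higher from compound 1 to compound 4 (within the scatter) and so leaves the two compounds within the scatter of each other, on the evidence of this single pair. No accompanying measurement speaks to the reason for this. Open, as far as these compounds go, is how an amine, a carboxylic acid or a longer chain would read at this place. Also open, from the compounds shown here alone, is whether the same exchange gives a similar step on another core.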